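Branching the Butyl Chain: Compound 3 to Compound 4

The compounds below may be only part of what the source reports. "The series", "measured", "known", "first", "only" and "open" are said of these compounds alone.

Measured compounds:
Compound 1, `CCN(CC)c1ccc(N2C(=O)NC3(CSC4=C3C(=O)c3ncccc3C4=O)C2=O)cc1`, gives 8 nM in a functional assay on MT4 cells (Homo sapiens) for antiproliferative activity, read by MTT assay, with a stated time of 96 h; a higher number here means a weaker inhibitor, a lower number a stronger inhibitor.
Compound 2, `Cc1ccc(N2C(=O)NC3(CSC4=C3C(=O)c3ncccc3C4=O)C2=O)cc1`, gives 27 nM.
Compound 3, `CCCCc1ccc(N2C(=O)NC3(CSC4=C3C(=O)c3ncccc3C4=O)C2=O)cc1`, gives 200 nM.

Of these three, compound 3 shows the highest number, meaning the weakest inhibition: compound 2 sits at a 7.4-fold higher number from compound 2 to compound 3 (0.87 log units; beyond the scatter) below it, and compound 1 further still, at a 25-fold higher number from compound 1 to compound 3 (1.40 log units; beyond the scatter). The next compound, compound 4, `CC(C)(C)c1ccc(N2C(=O)NC3(CSC4=C3C(=O)c3ncccc3C4=O)C2=O)cc1`, keeps every atom of compound 3 and only rearranges the four-carbon group: tert-butyl in place of butyl on an aromatic carbon.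

Within the data shown here, two measured steps touch this position. The step from compound 2 to compound 3, a 7.4-fold higher number from compound 2 to compound 3 (0.87 log units; beyond the scatter), shows that extending the chain on this aromatic carbon weakens inhibition. The step from compound 1 to compound 3, a 25-fold higher number from compound 1 to compound 3 (1.40 log units; beyond the scatter), shows the same direction more strongly. Neither step, however, compares a straight chain with a branched one of the same size, so there is no direct guide for compound 4.

With the atom count unchanged, the expected step from compound 3 to compound 4 is small, a 1.1-fold lower number from compound 3 to compound 4 (0.05 log units; within the scatter), and not clearly beyond the usual scatter in either direction. Compound 4 is therefore estimated at 180 nM, with a range from 60 nM to 600 nM.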

Compound 4, half-maximal inhibitory concentration: 200 nM
The estimate for compound 4 lay 1.1-fold (0.05 log units) below the measured number; measured number inside the range.
By their numbers in this assay, from the lowest: compound 1; then compound 2; then compounds 3 and 4 (each within the scatter of the next).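

Moving the same four carbons from a straight butyl chain to a compact tert-butyl group gives no change at the digits printed from compound 3 to compound 4 (within the scatter) in this assay, so at this aromatic carbon these two shapes cannot be told apart. Compound 4 also reproduces the gaps seen for the straight chain, with a 7.4-fold higher number from compound 2 to compound 4 (0.87 log units; beyond the scatter) against the methyl group and a 25-fold higher number from compound 1 to compound 4 (1.40 log units; beyond the scatter) against the diethylamino group , which means that the higher numbers of the four-carbon compounds hold for both the straight and the branched arrangement. Nothing measured alongside these compounds explains why butyl and tert-butyl match or why both sit above methyl and diethylamino.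

The compounds shown jump from methyl straight to four-carbon groups, so it remains open how the number moves through ethyl, propyl or isopropyl, and whether a longer chain such as hexyl would raise it further. They also leave open whether the low number of compound 1 extends to other amines, such as dimethylamino or morpholine, or to an oxygen-linked group such as methoxy.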